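Replacing 1-methylpyrrolidin-2-yl with ethyl on a carbonyl carbon

The compounds below may be only part of what the source reports. "The series", "measured", "known", "first", "only" and "open" are said of these compounds alone.

Measured in an ADME assay on microsomes from liver (Mus musculus) for pharmacokinetics, read by LC-MS, using NADPH, with stated times of 5 min, 15 min and 30 min, tested at 10 uM; on this read-out lower numbers stand for slow clearance and higher numbers for fast clearance:
- Compound 1 `C[C@H](NC(=O)c1ncccn1)c1ccc(NC(=O)N2CC(c3ccc(N)nc3)C2)cc1`: < 25 mL.min-1.g-1
- Compound 2 `C[C@H](NC(=O)[C@@H]1CCCN1C)c1ccc(NC(=O)N2CC(c3ccc(N)nc3)C2)cc1`: < 25 mL.min-1.g-1

Compound 2 gives < 25 mL.min-1.g-1, which is a limit of the assay and not a number. Compound 1 gives < 25 mL.min-1.g-1, which is also a limit. Together they make up (the limit of < 25 mL.min-1.g-1 in this assay, at which 2 of the 2 values shown sit).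

The next compound, compound 3 `CCC(=O)N[C@@H](C)c1ccc(NC(=O)N2CC(c3ccc(N)nc3)C2)cc1`, keeps the shared core and changes only the group on the carbonyl carbon: ethyl in place of 1-methylpyrrolidin-2-yl on a carbonyl carbon. That is ethyl in place of 1-methylpyrrolidin-2-yl.

Going by the values given here, the one measured step that bears on this change is at the same carbonyl carbon: a step that the two limits leave unreadable from compound 1 to compound 2. Among the compounds with values here, it gives no usable size, so the data offer no sign of a step up or down. Swapping pyrimidin-2-yl for 1-methylpyrrolidin-2-yl left both compounds reported only as limits in this assay, so no shift beyond the usual scatter is expected here. The expected change is a step that the limit leaves unreadable from compound 2 to compound 3. For compound 3 the estimated clearance is 20 mL.min-1.g-1, with an expected range of 10 mL.min-1.g-1 to 45 mL.min-1.g-1.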

Compound 3, intrinsic clearance in microsomes: 22 mL.min-1.g-1
For compound 3 the middle estimate is 1.1-fold (0.04 log units) below the measured one, within the range that was stated.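

No step can be read from compound 3 to compound 1 or to compound 2 in this assay, because compound 1 and compound 2 are each reported as a limit and not as a number: (the limit of < 25 mL.min-1.g-1 in this assay, at which 2 of the 3 values shown sit). The compounds shown leave open whether changing the group on the carbonyl carbon alters clearance at all, and by how much.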